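The source may report more compounds than this note shows. Statements on the series, on what has been measured and on what is new or still open speak of the compounds shown alone.

Compound 1 `C=C(Br)C(=O)Nc1cccc(/C=C/C(=O)Nc2ccccc2)c1` gives 5000 nM
Compound 2 `C=C(Br)C(=O)Nc1cccc(/C=C/C(=O)Nc2cccc(F)c2)c1` gives 1000 nM
Compound 3 `C=C(Br)C(=O)Nc1cccc(/C=C/C(=O)Nc2ccc(F)c(F)c2)c1` gives 550 nM

All three values come from a functional assay on Jurkat cells (Homo sapiens) for inhibition, read by MTT assay, with a stated time of 72 h; on this read-out lower numbers stand for stronger inhibition and higher numbers for weaker inhibition. Two steps place compound 3: a 9.1-fold lower number from compound 1 to compound 3 (0.96 log units; beyond the scatter) and a 1.8-fold lower number from compound 2 to compound 3 (0.26 log units; within the scatter). It therefore stands clear of only one of the other two compounds.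

The next structure is compound 4 `C=C(Br)C(=O)Nc1cccc(/C=C/C(=O)NCc2ccc(C)cc2)c1`, and the change is 4-methylbenzyl in place of 3,4-difluorophenyl on an amide-type nitrogen. This is 4-methylbenzyl in place of 3,4-difluorophenyl on an amide-type nitrogen. Within the data shown here, no measured compound carries 4-methylbenzyl, so the evidence is indirect. The nearest steps are changes at the same group: a 5.0-fold lower number from compound 1 to compound 2 (0.70 log units; beyond the scatter) and the modest step already given for 3,4-difluorophenyl in place of phenyl. Compound 4 has no fluoro group, and compound 1, also without one, gives 5000 nM. Part of that modest gain is therefore expected to be lost, though the benzyl linkage itself is untested. For compound 4 the expected step is a 3.6-fold higher number from compound 3 to compound 4 (0.56 log units; beyond the scatter) and points to weaker inhibition. Compound 4 is estimated at 2000 nM (range 500 nM to 8000 nM).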

Compound 4, half-maximal inhibitory concentration: 740 nM
For compound 4 the middle estimate is 2.7-fold (0.43 log units) above the measured one, and the stated range covers the measured number.
By their numbers in this assay, from the lowest: compounds 3, 4 and 2 (each within the scatter of the next); then compound 1.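

On the amide-type nitrogen, whose other neighbour is the carbonyl carbon, the steps of a 1.3-fold higher number from compound 3 to compound 4 (0.13 log units; within the scatter) and a 1.4-fold lower number from compound 2 to compound 4 (0.13 log units; within the scatter) in this assay place 4-methylbenzyl level with both fluorinated groups. The step of a 6.8-fold lower number from compound 1 to compound 4 (0.83 log units; beyond the scatter) shows that fluoro is not required at this position to stand clear of compound 1, as a group of 8 carbon heavy atoms does so too. No measurement on hand accounts for this match between fluorinated aryl and methylbenzyl groups.

The shown compounds cannot separate the contribution of the benzyl linkage from that of the methyl group, as plain benzyl and 3,4-difluorobenzyl are absent from the set. Also open, from the compounds shown here alone, is how this nitrogen tolerates a longer chain to the ring, or an amine or a carboxylic acid on the ring.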